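The source may hold more compounds than are shown below. What is called first, only, known or untested is meant among the compounds shown, and "the series" means these compounds.

Working notes on the series. The shared core is carried by compound 1 `CCOC(=O)c1cnc(N2CCN(Cc3ccc(C#N)cc3)CC2)nc1Oc1c(C)cc(-c2ccc(C#N)cc2)cc1C`, compound 2 `CCOC(=O)c1cnc(N2CCN(Cc3ccccc3C#N)CC2)nc1Oc1c(C)cc(-c2ccc(C#N)cc2)cc1C` and compound 3 `CCOC(=O)c1cnc(N2CCN(Cc3cccc(C(F)(F)F)c3)CC2)nc1Oc1c(C)cc(-c2ccc(C#N)cc2)cc1C`, which differ only in the aryl group on a saturated chain carbon bound to an amine nitrogen in a ring. In an ADME assay on MT4 cells (Homo sapiens) for cytotoxicity, read by MTT assay, with a stated time of 4 days (a lower number here means that less compound is tolerated, a higher number that more compound is tolerated), compound 1 gives > 125000 nM, a limit of the assay rather than a number. In this assay compound 2 gives > 125000 nM, likewise a limit. In this assay compound 3 gives > 125000 nM, again a limit. Compound 3 thus stands where the whole series stands, at the limit of > 125000 nM in this assay, at which 3 of the 3 values shown sit; no value among the three is a number. The steps a step that the two limits leave unreadable from compound 1 to compound 2, a step that the two limits leave unreadable from compound 1 to compound 3 and a step that the two limits leave unreadable from compound 2 to compound 3 are not readable in size; the limits hide them. Compound 4 `CCOC(=O)c1cnc(N2CCN(Cc3ccccc3C(F)(F)F)CC2)nc1Oc1c(C)cc(-c2ccc(C#N)cc2)cc1C` has not been measured in this assay and differs from compound 3 by 2-(trifluoromethyl)phenyl in place of 3-(trifluoromethyl)phenyl on a saturated chain carbon bound to an amine nitrogen in a ring. The three measured steps bear on it only insofar as each aryl swap at that carbon left the limit in place; no step size is available. No step beyond the scatter is therefore expected from compound 3 to compound 4, a number no higher from compound 3 to compound 4 (the limit leaves the size open). Compound 4 is expected at 125000 nM, within 60000 nM to 250000 nM, most probably reported again only as a limit.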

Compound 4, half-maximal cytotoxic concentration: > 125000 nM
Compound 4 ended at the assay's limit; the forecaster's own chance of this, stated with the estimate: 85%; the middle value sits exactly at the limit.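

No new step can be read: the steps from compound 1, compound 2 and compound 3 to compound 4 are all hidden by limits in this assay, and the series stands at one value: the limit of > 125000 nM in this assay, at which 4 of the 4 values shown sit. The compounds shown leave open how far these aryl groups differ in this assay, with no value among the four a number.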